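From compound 3 to compound 4: a methyl step

The source may report more compounds than this note shows. Statements on the series, on what has been measured and on what is new or still open speak of the compounds shown alone.

In a functional assay on K562 cells (Homo sapiens) for cytotoxicity, read by XTT assay, with a stated time of 24 h (a higher number here means a weaker inhibitor, a lower number a stronger inhibitor), compound 3 `Cc1ccc(NC(=O)c2ccccc2OCCCCn2ccnc2)cc1Nc1nccc(-c2cccnc2)n1` gives 47500 nM. Compound 1 `Cc1ccc(NC(=O)c2ccc(Br)cc2OCCCCn2ccnc2)cc1Nc1nccc(-c2cccnc2)n1` gives 66100 nM, and compound 2 `Cc1ccc(NC(=O)c2ccc([N+](=O)[O-])c(OCCCCn3ccnc3)c2)cc1Nc1nccc(-c2cccnc2)n1` gives 25000 nM. Compound 3 therefore holds the middle of the three numbers, within the scatter of each of the other two.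

Compound 4 `Cc1ccc(OCCCCn2ccnc2)c(C(=O)Nc2ccc(C)c(Nc3nccc(-c4cccnc4)n3)c2)c1` differs from compound 3 in one place: methyl in place of hydrogen on an aromatic carbon. This is methyl in place of hydrogen on an aromatic carbon, para to a 4-(1H-imidazol-1-yl)butoxy group.

Within the data shown here, only one measured single-place step bears on this change: a 1.4-fold lower number from compound 1 to compound 3 (0.14 log units; within the scatter), hydrogen in place of bromo on an aromatic carbon, which stays within the scatter. Among the measured compounds shown here, compound 2 differs from compound 3 in more than one place and gives no such step. For the measured compounds named here, no measured step covers methyl itself, so the evidence is indirect. On that basis, no step beyond the scatter is expected in this assay, and no direction is favoured.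

The expected size is a 1.1-fold lower number from compound 3 to compound 4 (0.02 log units; within the scatter).

Compound 4 is estimated at 45000 nM, with an expected range of 22000 nM to 90000 nM.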

Compound 4, half-maximal inhibitory concentration: 59500 nM
Estimate against measurement, compound 4: 1.3-fold (0.12 log units) below; measured number inside the range.
By their numbers in this assay, from the lowest: compounds 2, 3, 4 and 1 (each within the scatter of the next, the first and the last beyond it).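

In this assay, among these compounds, methyl in place of hydrogen, para to a 4-(1H-imidazol-1-yl)butoxy group, gives a 1.3-fold higher number from compound 3 to compound 4 (0.10 log units; within the scatter) and so provides the first direct reading of a methyl at this position. Among the compounds shown here, with a 1.4-fold lower number from compound 1 to compound 3 (0.14 log units; within the scatter) as the only other single-place step, neither change on this six-membered aromatic ring of carbon only, bromo nor methyl, moves the number beyond the scatter, though these two changes do not sit at the same place. No measurement at hand accounts for the size of the step from hydrogen to methyl.

Going by these compounds, it remains open whether an amine, a carboxylic acid or a longer alkyl chain at this position would give a step beyond the scatter. The compounds shown also leave open how a shorter or longer chain in place of the 4-(1H-imidazol-1-yl)butoxy group would read in this assay.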